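The compounds below may be only part of what the source reports. "The series", "measured", "known", "first", "only" and "open" are said of these compounds alone.

Working notes on the series, which shares one core and varies the group on the amide nitrogen. In a functional assay on MDA-MB-231 cells (Homo sapiens) for antiproliferative activity, read by MTT assay, with a stated time of 72 h (a lower number here means a stronger inhibitor, a higher number a weaker inhibitor), compound 1 (`CCNC(=O)CCc1cccc2c1B(O)OC2`) gives > 100000 nM, a limit of the assay and not a number. Compound 2 (`CC(C)(C)NC(=O)CCc1cccc2c1B(O)OC2`) gives > 100000 nM, again a limit. Compound 3 (`O=C(CCc1cccc2c1B(O)OC2)NC1CCCCC1`) gives > 100000 nM, also a limit, so its position is known only as a bound. Among the compounds with values here, the series so far rests on one line: the limit of > 100000 nM in this assay, at which 3 of the 3 values shown sit.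

The next change leads from compound 3 to compound 4 (`O=C(CCc1cccc2c1B(O)OC2)Nc1ccccc1`), with phenyl in place of cyclohexyl on an amide-type nitrogen.

Three measured steps at the same nitrogen bear on it: a step that the two limits leave unreadable from compound 1 to compound 2, a step that the two limits leave unreadable from compound 1 to compound 3 and a step that the two limits leave unreadable from compound 2 to compound 3. None has a readable size, so they set no scale for the new change. Within the data shown here, none of compound 1, compound 2 or compound 3 carries an aromatic ring at this place, so the new group has no measured precedent here. Remaining at the limit in this assay is the slightly likelier outcome, and any readable change is expected toward stronger inhibition. The estimated step is an at least 2.0-fold lower number from compound 3 to compound 4 (0.30 log units; that floor lies within the scatter), and its size is weakly grounded. For compound 4 the expected value is 50000 nM, with an estimated range of 8000 nM to 120000 nM.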

Compound 4, half-maximal inhibitory concentration: 230 nM
Estimate against measurement, compound 4: 220-fold (2.34 log units) above; measured number below the stated range.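

Within the data shown here, compound 4 gives the first readable number of the series in this assay, which shows that the group on the amide-type nitrogen can move the read-out far from the limit. Exchanging the non-aromatic six-membered carbon ring for the aromatic one gives an at least 430-fold lower number from compound 3 to compound 4 (2.63 log units; beyond the scatter), and the size is a floor, as the starting point is only a limit. Phenyl stands equally clear of the two other groups, with an at least 430-fold lower number from compound 2 to compound 4 (2.63 log units; beyond the scatter) for tert-butyl and an at least 430-fold lower number from compound 1 to compound 4 (2.63 log units; beyond the scatter) for ethyl, while the steps among compound 1, compound 2 and compound 3 cannot be read, so phenyl is the only group shown that leaves the line on which the other three compounds rest: the limit of > 100000 nM in this assay, at which 3 of the 4 values shown sit.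

With phenyl the only aromatic group shown at this place, it remains open whether a pyridine ring, a phenyl carrying a methoxy or chloro group, or a benzyl group would hold a number of this order. Also open, on these data alone, is how much of the effect depends on the shared core and its propanamide chain, for instance whether a longer chain would keep it.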